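Methyl for Methoxy: One Step on the Shared Core

A few compounds are considered here, and "the series" means these few. Any claim that something is new, unique, unknown or untested is made for them only; others in the source may bear on it.

- Compound 1 `COc1c(-c2ccc(C(F)(F)F)cc2Cl)ccc2c1cnn2[C@@H](CC(C)C)c1ccc(C(=O)NCCC(=O)O)cc1`: 97%
- Compound 2 `Cc1cc(C(F)(F)F)ccc1-c1ccc2nn([C@@H](CC(C)C)c3ccc(C(=O)NCCC(=O)O)cc3)cc2c1C`: 107%

Both compounds were tested in an ADME assay on microsomes from liver (Rattus norvegicus) for metabolic stability, with a stated time of 10 min, tested at 1 uM; on this read-out lower numbers stand for a less stable compound and higher numbers for a more stable compound. Compound 1 gives 97% and compound 2 gives 107%. These two values lie within the usual scatter of each other, so the numbers do not separate compound 1 from compound 2, its nearest and only neighbour in the data.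

The next compound is compound 3 `Cc1c(-c2ccc(C(F)(F)F)cc2Cl)ccc2c1cnn2[C@@H](CC(C)C)c1ccc(C(=O)NCCC(=O)O)cc1`, which has not yet been measured. It carries methyl in place of methoxy on an aromatic carbon, ortho to a 2-chloro-4-(trifluoromethyl)phenyl group (methyl in place of methoxy on an aromatic carbon). For the measured compounds named here, no measured pair shows this change on its own, so the data give no direct guide to its size or direction in this assay.

The expectation therefore rests on the general level of the series, with compound 1 at 97% and compound 2 at 107%. The expected step of a number 1 percentage points higher from compound 1 to compound 3 (within the scatter) is no larger than the scatter, in either direction. For compound 3 the estimated value is 98%, with an expected range of 85% to 110%.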

Compound 3, percent of the compound remaining: 87%
The estimate for compound 3 lay 11 percentage points above the measured number, within the range that was stated.
By their numbers in this assay, from the lowest: compounds 3, 1 and 2 (each within the scatter of the next, the first and the last beyond it).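

In this assay, for the compounds shown here, the pair of compound 1 and compound 3 gives the first direct reading of methyl in place of methoxy on this aromatic carbon, ortho to a 2-chloro-4-(trifluoromethyl)phenyl group: a number 10 percentage points lower from compound 1 to compound 3 (within the scatter). The two compounds differ in this one place, so the step belongs to this change alone: methoxy, with its hydrogen-bond acceptor, gives way to methyl, which carries no hydrogen-bond acceptor, and the step stays within the scatter of this read-out on the shared core. Nothing measured here bears on what lies behind the size of this step.

The compounds shown leave open how an amine, a hydroxyl group or a longer chain such as ethyl on this same aromatic carbon would read in this assay, since only methoxy and methyl are seen there. Going by these compounds alone, they also leave open whether the same change would give a similar step with a different aryl group at the neighbouring place named above, as compound 2 differs from compound 1 and compound 3 in more than one place and forms no such pair.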